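The source may hold more compounds than are shown below. What is called first, only, known or untested is meant among the compounds shown, and "the series" means these compounds.

Of the compounds shown here, three have been measured. Compound 1 `COc1ccc(COc2cc(N)c(Cl)cc2C(=O)CCCCN2CCCCC2)cc1OC` gives 8.5 in a functional assay for antagonist activity at 5-hydroxytryptamine receptor 4 (Rattus norvegicus); on this read-out lower numbers stand for lower potency and higher numbers for higher potency (the scale is a negative logarithm). Among the compounds with values here, compound 2 `COc1ccc(CCOc2cc(N)c(Cl)cc2C(=O)CCCCN2CCCCC2)cc1OC` gives 6.8 in this assay, and the single step among them, a number 1.70 log units lower from compound 1 to compound 2 (beyond the scatter), is a large loss. Compound 3 `COc1cc(COc2cc(N)c(Cl)cc2C(=O)CCCCN2CCC(O)CC2)cc(OC)c1` gives 8.3 in this assay; it stands second highest of the three numbers, within the scatter of compound 1 and far above compound 2.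

Compound 4 `COc1cc(COc2cc(N)c(Cl)cc2C(=O)CCCCN2CCC(CCNS(C)(=O)=O)CC2)cc(OC)c1` has not been measured. Against compound 3 it carries 2-(methanesulfonamido)ethyl in place of hydroxy on a saturated ring carbon. Within the data shown here, the only measured step, a number 1.70 log units lower from compound 1 to compound 2 (beyond the scatter), concerns the group on the saturated chain carbon bound to an oxygen on an aromatic ring, a different place, and so offers no direct guide. Among the measured compounds shown here, no measured pair changes the substituent on the saturated ring carbon alone. Compound 1 and compound 3 differ in two places, one of them being the hydroxy on that ring carbon, and their values sit within the scatter of each other, which is the only hint that this ring position tolerates substitution.

On that basis the account expects no step beyond the scatter, no change at the digits printed from compound 3 to compound 4 (within the scatter). Compound 4 is estimated at 8.3, with a range from 7.5 to 9.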

Compound 4, negative logarithm of the antagonist equilibrium constant: 8.1
Estimate against measurement, compound 4: 0.20 log units above; the measured number falls inside the stated range.
By their numbers in this assay, from the lowest: compound 2; then compounds 4, 3 and 1 (each within the scatter of the next, the first and the last beyond it).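

Within the data shown here, the exchange of hydroxy for 2-(methanesulfonamido)ethyl on this saturated ring carbon, three ring bonds from the ring nitrogen, gives a number 0.20 log units lower from compound 3 to compound 4 (within the scatter) in this assay, the first direct reading of a change at this position. It shows that a group of seven heavy atoms can stand where a single oxygen stood, with hydrogen-bond acceptors going from one to two and the donor count unchanged, and that this assay cannot tell the two compounds apart. Nothing in the data given accounts for why the number holds across so large an exchange.

This single step leaves open whether other groups at this ring carbon, such as an amine, a carboxylic acid or a longer chain ending in the same methanesulfonamide, would also stay within the scatter of compound 3. It also leaves open whether 2-(methanesulfonamido)ethyl would behave the same way on the core of compound 1, which differs from compound 3 in two places and so gives no clean comparison.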